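The compounds below may be only part of what the source reports. "The series", "measured", "known", "first", "only" and "open" are said of these compounds alone.

Measured so far in a functional assay on MCF7 cells (Homo sapiens) for inhibition; on this read-out lower numbers stand for stronger inhibition and higher numbers for weaker inhibition:
- compound 1 `O=C(/C=C/c1ccc(I)cc1)c1ccc(OCB(O)O)cc1` gives 9500 nM
- compound 2 `O=C(O)COc1ccc(/C=C/C(=O)c2ccc(Cl)c(Cl)c2)cc1` gives 15000 nM

Compound 1 holds the lower of the two numbers, but its gap to compound 2 lies within the scatter, so neither compound can be set above the other.

Compound 3 `O=C(/C=C/c1ccc(I)cc1)c1ccc(B(O)O)cc1` is the next candidate. It differs from compound 1 by a group of 3 heavy atoms (1 boron, 2 oxygen; no ring) in place of a group of 5 heavy atoms (1 carbon, 1 boron, 3 oxygen; no ring), on an aromatic carbon. Within the data shown here, no measured pair follows such a change, so nothing fixes its size or direction. The expectation is a step of a 1.1-fold lower number from compound 1 to compound 3 (0.02 log units; within the scatter), not beyond the scatter. Compound 3 is therefore estimated at 9000 nM, within 3000 nM to 30000 nM.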

Compound 3, half-maximal inhibitory concentration: 7000 nM
For compound 3 the middle estimate is 1.3-fold (0.11 log units) above the measured one, and the stated range covers the measured number.
By their numbers in this assay, from the lowest: compounds 3, 1 and 2 (each within the scatter of the next, the first and the last beyond it).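

In this assay, among these compounds, replacing the group of 5 heavy atoms with the group of 3 heavy atoms on this aromatic carbon, para to a large group, gives a 1.4-fold lower number from compound 1 to compound 3 (0.13 log units; within the scatter) and so gives the first one-place reading. The two groups cannot be told apart on this read-out, so shortening the group here shows no measurable effect. No available measurement accounts for this result.

On these data alone, whether an amine or a longer chain at this aromatic carbon would move the number beyond the scatter stays open.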